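Moving from Compound 3 to Compound 4 in a Cell Assay

This account rests on a few compounds, and the source may have more. Where it says the series, first, only, none or still open, it means among the compounds named here.

Measured so far:
compound 1, `COc1ccc(CNC(=O)CN(c2cc(Cl)ccc2OC)S(=O)(=O)c2ccccc2)cc1`: > 20000 nM (a limit of the assay, not a number)
compound 2, `COc1ccc(Cl)cc1N(CC(=O)NC1CCCCC1)S(=O)(=O)c1ccccc1`: 17600 nM
compound 3, `COc1ccc(Cl)cc1N(CC(=O)N1CCCCC1)S(=O)(=O)c1ccccc1`: 14500 nM

In a functional assay on SH-SY5Y cells (Homo sapiens), read by MTT assay, with a stated time of 24 h (a lower number here means that less compound is needed, a higher number that more compound is needed for the effect), compound 3 gives 14500 nM. Compound 2 stands beside it at 17600 nM, and the step of a 1.2-fold lower number from compound 2 to compound 3 (0.08 log units; within the scatter) between them lies within the scatter. For compound 1 only a limit is recorded, > 20000 nM. Compound 4, `COc1ccc(Cl)cc1N(CC(=O)Nc1ccc(Cl)cc1)S(=O)(=O)c1ccccc1`, has not been measured; it differs from compound 3 by (4-chlorophenyl)amino in place of piperidin-1-yl on a carbonyl carbon. Going by the values given here, the steps that bear on this change are a 1.2-fold lower number from compound 2 to compound 3 (0.08 log units; within the scatter) and an at least 1.3-fold lower number from compound 1 to compound 3 (0.13 log units; that floor lies within the scatter), both exchanges of the group on the same carbonyl carbon and both small. A step of a 1.0-fold higher number from compound 3 to compound 4 (0.01 log units; within the scatter) is therefore expected, that is none beyond the scatter. Compound 4 is estimated at 15000 nM, with a range from 5000 nM to 40000 nM.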

Compound 4, half-maximal effective concentration: > 20000 nM
Compound 4: only a limit was reported (the forecaster's own chance of this, stated with the estimate: 35%); at least 1.3-fold (0.12 log units) between middle value and limit.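

In this assay compound 4 gives > 20000 nM, which is a limit of the assay and not a number. From the compounds shown here alone, the exchange gives an at least 1.3-fold higher number from compound 3 to compound 4 (0.13 log units; that floor lies within the scatter) and an at least 1.1-fold higher number from compound 2 to compound 4 (0.05 log units; that floor lies within the scatter), so (4-chlorophenyl)amino on this carbonyl carbon brings no measurable gain, though the true size of either step stays unknown. The aromatic amide thus becomes the second compound shown at that limit: the limit of > 20000 nM in this assay, at which 2 of the 4 values shown sit.

The step between compound 1 and compound 4 cannot be read, since both are limits. Going by these compounds, it also remains open whether a piperidine carrying an amine or a carboxylic acid would lower the number.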